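A few compounds are considered here, and "the series" means these few. Any claim that something is new, unique, unknown or untested is made for them only; others in the source may bear on it.

Measured so far in an ADME assay on microsomes from liver (Rattus norvegicus) for metabolic stability; on this read-out lower numbers stand for a less stable compound and higher numbers for a more stable compound:
compound 1 `CCCCCOC(=O)N1CCN(C(=O)[C@H](CCC(=O)O)NC(=O)c2cc(N3CCC(C(=O)N4CCCC4)CC3)nc(-c3ccccc3)n2)CC1` gives > 80% and this is a limit of the read-out.
compound 2 `CCCCCOC(=O)N1CCN(C(=O)[C@H](CCC(=O)O)NC(=O)c2cc(N3CCC(CNC)CC3)nc(-c3ccccc3)n2)CC1` gives > 80% and this too is a limit.

Compound 2 thus stands only at a limit, and both values shown sit there (the limit of > 80% in this assay, at which 2 of the 2 values shown sit). For the measured compounds named here, the single measured step, a step that the two limits leave unreadable from compound 1 to compound 2, has no readable size. The change to compound 3 `CCCCCOC(=O)N1CCN(C(=O)[C@H](CCC(=O)O)NC(=O)c2cc(N3CCC(C(N)=O)CC3)nc(-c3ccccc3)n2)CC1` is carbamoyl in place of (methylamino)methyl on a saturated ring carbon. Going by the values given here, with the one neighbouring step unreadable, no step beyond the scatter is expected, so compound 3 is estimated at 85% (range 68% to 96%), most probably again reported as a limit. The expected step is a step that the limit leaves unreadable from compound 2 to compound 3.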

Compound 3, percent of the compound remaining: > 80%
Compound 3 was reported as a limit; the forecaster's own chance of this, stated with the estimate: 70%; the middle value lies beyond the limit too.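

Compound 3 sits at the same limit as compound 1 and compound 2, so no step among these three can be read in this assay: the limit of > 80% in this assay, at which 3 of the 3 values shown sit.

The compounds shown leave open whether carbamoyl, (methylamino)methyl and (pyrrolidin-1-yl)carbonyl differ at all on this read-out.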